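The source may report more compounds than this note shows. Statements on the series, on what has been measured and on what is new or still open speak of the compounds shown alone.

In a functional assay on Shh Light II cells (Mus musculus) for inhibition, read by a luciferase reporter (on this read-out higher numbers stand for weaker inhibition and lower numbers for stronger inhibition), compound 3 `O=C(Nc1cccc2cccnc12)N1CCC(c2nc(-c3ccc4ccccc4n3)no2)CC1` gives 1400 nM. Among the compounds with values here, this value lies within the scatter of compound 1 `O=C(NC1CC[S+]([O-])CC1)N1CCC(c2nc(-c3ccc4ccccc4n3)no2)CC1` at 850 nM, while compound 2 `COc1ccccc1N(C)C(=O)N1CCC(c2nc(-c3ccc4ccccc4n3)no2)CC1` gives 3100 nM, the only value of the three set apart from both others. The change under consideration leads to compound 4 `O=C(NC1CCOCC1)N1CCC(c2nc(-c3ccc4ccccc4n3)no2)CC1`: oxan-4-yl in place of quinolin-8-yl on an amide-type nitrogen, with oxan-4-yl in place of quinolin-8-yl on an amide-type nitrogen. The most relevant measured comparison is a 1.6-fold higher number from compound 1 to compound 3 (0.22 log units; within the scatter), which lies within the scatter; there, quinolin-8-yl also stands on that nitrogen in place of a group with one six-membered non-aromatic ring with 1 hetero atom. Two steps involve the (2-methoxyphenyl)(methyl)amino group of compound 2 and bear only indirectly: a 3.6-fold higher number from compound 1 to compound 2 (0.56 log units; beyond the scatter) and a 2.2-fold lower number from compound 2 to compound 3 (0.35 log units; beyond the scatter), both modest. No change beyond the scatter is therefore expected in this assay, with a slight lean towards a lower number. The expected step is a 1.4-fold lower number from compound 3 to compound 4 (0.15 log units; within the scatter). Compound 4 is estimated at 1000 nM, with an expected range of 450 nM to 2200 nM.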

Compound 4, half-maximal inhibitory concentration: 480 nM
Compound 4: the middle estimate sits 2.1-fold (0.32 log units) above what was measured; measured number inside the range.
By their numbers in this assay, from the lowest: compounds 4, 1 and 3 (each within the scatter of the next, the first and the last beyond it); then compound 2.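

In this assay, within the data shown here, oxan-4-yl in place of quinolin-8-yl on the amide-type nitrogen is the first change at this nitrogen to go beyond the scatter (a 2.9-fold lower number from compound 3 to compound 4 (0.46 log units; beyond the scatter)), so this position does respond to the group it carries, although compound 1 and compound 3 could not be separated. The sulfur-containing ring of compound 1 and oxan-4-yl cannot be told apart (a 1.8-fold lower number from compound 1 to compound 4 (0.25 log units; within the scatter)), so a six-membered non-aromatic ring holds up with either hetero atom, though compound 3, with its aromatic rings, also stays within the scatter of compound 1. The widest step in the set comes with (oxan-4-yl)amino in place of (2-methoxyphenyl)(methyl)amino on the carbonyl carbon (a 6.5-fold lower number from compound 2 to compound 4 (0.81 log units; beyond the scatter)).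

No evidence at hand explains any of these steps. Open, going by these compounds, is whether the ring hetero atom matters at all, which a cyclohexyl or a piperidin-4-yl on this nitrogen would test.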